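A few compounds are considered here, and "the series" means these few. Any claim that something is new, unique, unknown or untested is made for them only; others in the source may bear on it.

Measured compounds, cytotoxicity on HeLa cells:

compound 1 `CN(C)C(=S)SC(=S)N1CCCC1`: 3090000 nM
compound 2 `CN(C)C(=S)SC(=S)N1CCCCCC1`: > 5000000 nM
compound 3 `CCOC(=O)N1CCN(C(=S)SC(=S)N(C)C)CC1`: 530000 nM

In an ADME assay on HeLa cells (Homo sapiens) for cytotoxicity, read by MTT assay, with a stated time of 24 h (a lower number here means a stronger inhibitor, a higher number a weaker inhibitor), compound 3 holds the lower of the two numbers shown. Compound 1 sits at the higher number. For compound 2 the result is a limit of the assay, not a number (the limit of > 5000000 nM in this assay, at which 1 of the 3 values shown sits). For the measured compounds named here, no step between two measured compounds that differ in one place is available, so no measured step size guides the next move.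

Compound 4 `CN(C)C(=S)SC(=S)N1CCN(C(=O)c2ccco2)CC1` is not yet measured. It differs from compound 3 in one place: furan-2-yl in place of ethoxy on a carbonyl carbon. The step from compound 3 to compound 4 is expected to be small, within the scatter or slightly toward a lower number, as a 1.3-fold lower number from compound 3 to compound 4 (0.12 log units; within the scatter). Compound 4 is estimated at 400000 nM, within 100000 nM to 1500000 nM.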

Compound 4, half-maximal inhibitory concentration: 2380000 nM
Estimate against measurement, compound 4: 6.0-fold (0.77 log units) below; the measured number lies above the stated range.
By their numbers in this assay, from the lowest: compound 3; then compounds 4 and 1 (each within the scatter of the next). At a limit, above all of these: compound 2.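

In this assay, for the compounds shown here, furan-2-yl in place of ethoxy on a carbonyl carbon gives a 4.5-fold higher number from compound 3 to compound 4 (0.65 log units; beyond the scatter) and is the first single change that can be read. The number therefore responds to the group on this carbonyl carbon, and the lower number of compound 3 does not carry over to a furan-2-yl carbonyl. Nothing measured here accounts for the step. On these data alone, it remains open whether a longer chain such as butoxy keeps the number of compound 3. Also open, as far as these compounds go, is whether a phenyl ring or an amine on the same carbonyl carbon moves the number as furan-2-yl does.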